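A few compounds are considered here, and "the series" means these few. Any claim that something is new, unique, unknown or untested is made for them only; others in the source may bear on it.

Working notes on the series. The compounds share one core, carrying an anilino group and an ethyl ester on the ring and a benzylidene-type arm on the ring sulfur side; they differ only in the aromatic group on that arm. Compound 1 is `CCOC(=O)C1=C(Nc2ccccc2)S/C(=C\c2ccc(O)c(O)c2)C1=O`, compound 2 is `CCOC(=O)C1=C(Nc2ccccc2)S/C(=C\c2cc(OC)ccc2OC)C1=O`, compound 3 is `CCOC(=O)C1=C(Nc2ccccc2)S/C(=C\c2ccccc2C(F)(F)F)C1=O`, and the unmeasured compound 4 is `CCOC(=O)C1=C(Nc2ccccc2)S/C(=C\c2cc3ncccc3[nH]2)C1=O`.

In a functional assay on MCF7 cells (Homo sapiens) for inhibition, read by MTT assay, with a stated time of 72 h, tested at 10 uM (on this read-out higher numbers stand for more inhibition at the one concentration tested (going by the name of the read-out) and lower numbers for less inhibition), compound 1 gives 38.1%. Compound 2 gives < 10% in this assay, which is a limit of the assay and not a number. Compound 3 likewise gives < 10% in this assay, again a limit. Among the measured compounds shown here, compound 1 thus stands as the only compound with a measured number; the other two sit at the limit of < 10% in this assay, at which 2 of the 3 values shown sit. For the measured compounds named here, no step between two measured compounds differing in one place is available, so the weight of any single change in this assay is not known from the data.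

Compound 4 differs from compound 1 by a group of 9 heavy atoms (7 carbon, 2 nitrogen; one five-membered aromatic ring with 1 hetero atom, one six-membered aromatic ring with 1 hetero atom) in place of a group of 8 heavy atoms (6 carbon, 2 oxygen; one six-membered aromatic ring of carbon only), on a double-bonded chain carbon bound to a double-bonded ring carbon. Going by the values given here, the 3,4-dihydroxyphenyl group of compound 1 is the only one paired with a number above the limit, and the two compounds that carry a six-membered aromatic ring of carbon only with other substituents both sit at the limit. Among the compounds with values here, with no measured step to lean on, a step in this assay of moderate size, more likely downward than upward, is expected from compound 1 to compound 4, namely a number 16.1 percentage points lower from compound 1 to compound 4 (beyond the scatter). Compound 4 is therefore expected to give about 22% in this assay, with a range from 5% to 42%.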

Compound 4, a percentage reported as inhibition, at one concentration (the size of the read-out at that concentration, not a potency): 42.2%
Compound 4: middle estimate off by 20.2 percentage points, on the low side; measured number outside the range, above it.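

In this assay, the replacement at this place gives a number 4.1 percentage points higher from compound 1 to compound 4 (within the scatter), so the two groups cannot be told apart on this read-out. Among the compounds shown here, the 3,4-dihydroxyphenyl group is therefore not the only group on a double-bonded chain carbon bound to a double-bonded ring carbon that is paired with a number, and the group in compound 4 reaches such a number with 2 nitrogen atoms and no oxygen. Compound 2 and compound 3 remain at a limit of the assay, not a number: the limit of < 10% in this assay, at which 2 of the 4 values shown sit.

Going by these compounds, what a plain phenyl, a pyridyl or a pyrrolyl group would give at this place remains open, so it is unclear which part of the fused group in compound 4 matters. With only one concentration shown, the potency of compound 1 and compound 4 also remains open.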